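The source may hold more compounds than are shown below. What is called first, only, known or untested is meant among the compounds shown, and "the series" means these compounds.

Of the compounds shown here, two have been measured in a functional assay on HEK293 cells for negative allosteric modulation of metabotropic glutamate receptor 5 (Homo sapiens), read by FLIPR and calcium flux; a higher number here means a weaker inhibitor, a lower number a stronger inhibitor. Compound 1 `Cc1ccc(C#Cc2ccc3c(n2)CCN(C)C3=O)cc1` gives 1400 nM. Going by the values given here, compound 2 `CN1CCc2nc(C#Cc3ccccn3)ccc2C1=O` gives 184 nM, the lowest of the two numbers, and its only neighbour is compound 1; the step between them is a 7.6-fold lower number from compound 1 to compound 2 (0.88 log units; beyond the scatter). Compound 3 `CN1CCc2nc(C#Cc3cccnc3)ccc2C1=O` has not been measured yet. It differs from compound 2 in a single place: pyridin-3-yl in place of pyridin-2-yl on a triple-bonded carbon. The two compounds contain the same atoms, joined differently.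

Among the compounds with values here, no measured step touches the position of the nitrogen within a pyridinyl ring; the one measured step, a 7.6-fold lower number from compound 1 to compound 2 (0.88 log units; beyond the scatter), swaps a whole ring and shows only that the group on the triple-bonded carbon can move the number by a modest amount. A change of nitrogen placement within the same ring is therefore expected to move the number as well, most likely upward, but with wide uncertainty, giving an expected step of a 6.5-fold higher number from compound 2 to compound 3 (0.81 log units; beyond the scatter). For compound 3 the estimated value in this assay is 1200 nM, within a range from 200 nM to 8000 nM.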

Compound 3, half-maximal inhibitory concentration: "not active" (no number reported)
No number was reported for compound 3; no gap can be computed for the estimate.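

In this assay, going by these compounds alone, compound 3 is reported only as "not active", with no number, so no step from compound 2 to compound 3 can be read. Nothing measured here explains this result. The compounds shown leave open how large the effect of pyridin-3-yl in place of pyridin-2-yl actually is.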